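A few compounds are considered here, and "the series" means these few. Any claim that something is new, unique, unknown or untested is made for them only; others in the source may bear on it.

Compound 1 `C/C(=N\NC(=O)NCCCC(=O)O)c1ccccc1` was examined in a functional assay on the whole organism (strain Swiss Albino) for inhibition, with Mus musculus as the target, in the writhing test, at a dose of 100 mg/kg by the intraperitoneal route (a higher number here means more inhibition at the dose given (going by the name of the read-out), a lower number less inhibition), where compound 1 gives 82%. Within the data shown here, its only measured neighbour is compound 2 `C/C(=N\NC(=O)NCCCC(=O)O)c1ccc(C)cc1`, which in this assay gives 82%, so on the numbers at hand compound 1 stands level with compound 2, and the step of no change at the digits printed from compound 1 to compound 2 (within the scatter) lies within the scatter. Compound 3 `C/C(=N\NC(=O)NCCCC(=O)O)c1cccc(N)c1` has not yet been measured; it differs from compound 1 by amino in place of hydrogen on an aromatic carbon. Among the measured compounds shown here, the only measured step that bears on this change is the substitution on the aromatic ring already seen, no change at the digits printed from compound 1 to compound 2 (within the scatter), which was flat. For the measured compounds named here, an amino group is a different substituent from a methyl, and no measured step speaks directly to it, so the expectation rests on the flat step alone. Compound 3 is therefore expected to give about 78%, with a range from 60% to 90%. The expected step of a number 4 percentage points lower from compound 1 to compound 3 (within the scatter) is thus estimated to stay within the scatter.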

Compound 3, a percentage reported as inhibition, in the whole organism at one dose (the size of the read-out at that dose, not a potency): 89%
Compound 3: middle estimate off by 11 percentage points, on the low side; the range from low to high includes it.
By their numbers in this assay, from the lowest: compounds 1, 2 and 3 (each within the scatter of the next).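

In this assay, amino in place of hydrogen on an aromatic carbon, meta to a large group, gives a number 7 percentage points higher from compound 1 to compound 3 (within the scatter), so this place on the ring accepts a group with a hydrogen-bond donor and acceptor while the read-out stays within the scatter. Alongside no change at the digits printed from compound 1 to compound 2 (within the scatter), this is a second substitution on the ring that does not move the read-out beyond the scatter, now with a nitrogen group rather than a carbon group. Nothing measured on these compounds accounts for this result.

The compounds shown leave open whether a chlorine, a hydroxyl or a nitro group at this same place would also stay within the scatter. They also leave open what happens when the carboxylic acid gives way to an ester or an amide, or when its chain is made shorter or longer.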